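Lengthening an Alkoxy Chain on a Shared Core

The source may report more compounds than this note shows. Statements on the series, on what has been measured and on what is new or still open speak of the compounds shown alone.

Of the compounds shown here, two built on the same core have been measured in a functional assay on mitochondria (Cricetulus griseus) for inhibition of Monoamine oxidase (Homo sapiens), tested at 0.9 uM; a lower number here means a weaker effect, a higher number a stronger effect of the compound at the concentration tested. Compound 1 `CCOc1ccc2c(=O)c(-c3ccc(O)cc3)coc2c1` carries an ethoxy group on its aromatic ring, and in this assay compound 1 gives 86.9%, the higher of the two numbers. Compound 2 `O=c1c(-c2ccc(O)cc2)coc2cc(CC3OC(CO)C(O)C(O)C3O)ccc12` carries a sugar-like substituent instead, and in this assay compound 2 gives 0%, a drop beyond the usual scatter. Compound 3 `O=c1c(-c2ccc(O)cc2)coc2cc(OCCCCCCBr)ccc12` has not yet been measured. Relative to compound 1 it differs in one place: 4-bromobutyl in place of hydrogen on a saturated chain carbon, two bonds along the chain from an oxygen on an aromatic ring. The oxygen on the aromatic ring is kept; only the chain beyond it grows. Because compound 1 reaches 86.9% with its short chain, the step from compound 1 to compound 3 is expected to be small, a number 8.9 percentage points lower from compound 1 to compound 3 (within the scatter), with some risk of a loss. Compound 3 is therefore estimated to give 78% in this assay, within 50% to 95%.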

Compound 3, a percentage reported as inhibition, at one concentration (the size of the read-out at that concentration, not a potency): 71.2%
The estimate for compound 3 lay 6.8 percentage points above the measured number, and the stated range covers the measured number.
By their numbers in this assay, from the lowest: compound 2; then compound 3; then compound 1.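

In this assay the change from ethoxy to (6-bromohexyl)oxy gives a number 15.7 percentage points lower from compound 1 to compound 3 (beyond the scatter) and so shows that lengthening the chain at this position carries a real but modest cost. Compound 3 still gives 71.2% at this single concentration, so the effect survives a much longer chain ending in bromine. Nothing measured here explains the drop.

A single long chain cannot show whether the loss builds gradually with length, as a butoxy group of intermediate size might reveal, or appears only near the full length. These compounds also cannot separate the length of the chain from its bromine end, a question that a plain hexyloxy chain, or the same chain ending in an amine or a carboxylic acid, could address.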